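The source may hold more compounds than are shown below. What is called first, only, known or untested is meant among the compounds shown, and "the series" means these compounds.

In a functional assay on isolated protein for antagonist activity at C-C chemokine receptor type 9 (Homo sapiens), read by calcium flux, with a stated time of 10 min (a lower number here means a stronger inhibitor, a higher number a weaker inhibitor), the three measured compounds stand as follows:

Compound 1 `COc1ccnc(-c2cc(Cl)ccc2NS(=O)(=O)c2ccc(C(C)(C)C)cc2)c1`: 2500 nM
Compound 2 `CC(C)(C)c1ccc(S(=O)(=O)Nc2ccc(Cl)cc2-c2c(O)ccc[n+]2[O-])cc1`: 491 nM
Compound 3 `CC(C)(C)c1ccc(S(=O)(=O)Nc2ccc(Cl)cc2-c2nccnc2NCCO)cc1`: 34 nM

Compound 3 has the lowest number of the three. The two steps that lead to it are both large: a 74-fold lower number from compound 1 to compound 3 (1.87 log units; beyond the scatter) and a 14-fold lower number from compound 2 to compound 3 (1.16 log units; beyond the scatter). The smaller step, a 5.1-fold lower number from compound 1 to compound 2 (0.71 log units; beyond the scatter), also lies beyond the scatter. All three steps exchange the whole six-membered ring attached to the shared core, so they show that this ring governs the number, but none of them varies a substituent on the ring of compound 3.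

Compound 4 `CNc1cnc(-c2cc(Cl)ccc2NS(=O)(=O)c2ccc(C(C)(C)C)cc2)c(NCCO)n1` keeps that ring and differs from compound 3 in one place: methylamino in place of hydrogen on an aromatic carbon. Among the measured compounds shown here, no measured pair bears directly on such an addition. For the measured compounds named here, the ring that carries it is the one whose choice gave compound 3 its low number, and the (2-hydroxyethyl)amino group on the same ring is kept. Without a comparable step, only a modest movement is expected, in either direction, and quite possibly none beyond the scatter. The step from compound 3 to compound 4 is therefore estimated at a 1.1-fold lower number from compound 3 to compound 4 (0.05 log units; within the scatter). In this assay compound 4 is expected to give about 30 nM, within a range from 10 nM to 100 nM.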

Compound 4, half-maximal inhibitory concentration: 1010 nM
For compound 4 the middle estimate is 34-fold (1.53 log units) below the measured one; the whole stated range lies below it.
By their numbers in this assay, from the lowest: compound 3; then compound 2; then compound 4; then compound 1.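

In this assay, among the compounds shown here, the earlier compounds showed only that exchanging the whole ring attached to the shared core moves the number. The new result, a 30-fold higher number from compound 3 to compound 4 (1.47 log units; beyond the scatter), shows that a single addition to the kept ring can also produce a large step, even with the (2-hydroxyethyl)amino group left in place. The aromatic carbon next to the ring nitrogen and para to a large group is therefore not a position where methylamino leaves the low number of compound 3 intact, but nothing available here explains this loss.

The compounds shown leave open whether the loss belongs to methylamino itself or to any group on this carbon, a question that a methyl group, a chlorine atom or an unsubstituted amine at the same place would help to settle. They also leave open whether a longer chain such as ethylamino, or a carboxylic acid, would bring the number closer to that of compound 3 or move it further away.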